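The source may report more compounds than this note shows. Statements on the series, on what has been measured and on what is new or still open speak of the compounds shown alone.

In an assay on membranes from HEK293 cells for displacement of a labelled ligand from adenosine receptor A2b (Homo sapiens), read by scintillation counting, with a stated time of 30 min, tested at 1 uM (on this read-out lower numbers stand for less inhibition and higher numbers for more inhibition at the one concentration tested (going by the name of the read-out)), compound 1 `CC1=C(C(=O)NC(C)C)C(c2ccoc2)NC(=O)N1` gives 3%, and compound 2 `CC1=C(C(=O)OC2CCCCC2)C(c2ccco2)NC(=O)N1` gives 1% in this assay. Compound 2 shows the smaller of the two numbers, but its gap to compound 1 lies within the usual scatter, so the two cannot be told apart. Compound 3 `CC1=C(C(=O)OC2CCCCC2)C(c2ccoc2)NC(=O)N1` has the same atoms as compound 2, joined differently: furan-3-yl in place of furan-2-yl on a saturated ring carbon. Because compound 1, which already carries furan-3-yl, gives 3%, the expected step of a number 2 percentage points higher from compound 2 to compound 3 (within the scatter) should amount to nothing beyond the scatter. Compound 3 is therefore estimated at 3%, within a range from -6% to 12%.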

Compound 3, a percentage reported as inhibition, at one concentration (the size of the read-out at that concentration, not a potency): 4%
Compound 3: middle estimate off by 1 percentage points, on the low side, within the range that was stated.
By their numbers in this assay, from the lowest: compounds 2, 1 and 3 (each within the scatter of the next).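

In this assay furan-3-yl in place of furan-2-yl on the saturated ring carbon gives a number 3 percentage points higher from compound 2 to compound 3 (within the scatter) and so the two attachments of the furan cannot be told apart here. Cyclohexyloxy in place of isopropylamino on the carbonyl carbon gives a number 1 percentage points higher from compound 1 to compound 3 (within the scatter) and so these two groups cannot be told apart either. No evidence is available to explain these results. Open, as far as these compounds go, is whether an amine or a carboxylic acid on the saturated ring carbon in place of the furan would give a number beyond the scatter. The same question holds for a longer chain on the carbonyl carbon.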